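The source may hold more compounds than are shown below. What is called first, only, known or untested is meant among the compounds shown, and "the series" means these compounds.

Working notes on the series. In a functional assay on K562 cells (Homo sapiens) for cytotoxicity, read by MTT assay, with a stated time of 48 h (a lower number here means a stronger inhibitor, a higher number a weaker inhibitor), compound 1 `COC(=O)/C=C/c1ccc2c(c1)C(=O)C(=O)N2Cc1ccc(C)cc1` gives 40 nM. Compound 2 `COC(=O)/C=C/c1ccc2c(c1)C(=O)C(=O)N2Cc1ccc2ccccc2c1` shares the core of compound 1 and in this assay compound 2 gives 40 nM; the two values sit level at the digits shown and within the scatter, so no order between compound 1 and compound 2 is drawn. Compound 3 `CCCCc1ccc2c(c1)C(=O)C(=O)N2` is the shared core carrying a butyl chain and no further group, and in this assay compound 3 gives only a limit, > 10000 nM; this is the point (the limit of > 10000 nM in this assay, at which 1 of the 3 values shown sits), not a number, and nothing more is read from it.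

Going by the values given here, compound 4 `COC(=O)/C=C/c1ccc2c(c1)C(=O)C(=O)N2Cc1ccc(OC)cc1` is the one unmeasured member. It differs from compound 1 by methoxy in place of methyl on an aromatic carbon. Among the compounds with values here, no measured pair in the set tracks this kind of change, so the size of the step can only be expected, not read off. Given that compound 1 and compound 2 sit together in this assay despite a different group in the same part of the molecule, the step from compound 1 to compound 4 is expected to be small, with no direction beyond the scatter. Compound 4 is therefore estimated at 40 nM in this assay, expected to fall between 15 nM and 110 nM. The expected step is no change at the digits printed from compound 1 to compound 4 (within the scatter), essentially none beyond the scatter.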

Compound 4, half-maximal inhibitory concentration: 3 nM
The estimate for compound 4 lay 13-fold (1.12 log units) above the measured number; the measured number lies below the stated range.
By their numbers in this assay, from the lowest: compound 4; then compounds 1 and 2 (each within the scatter of the next). At a limit, above all of these: compound 3.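

In this assay, the change from 4-methylphenyl to 4-methoxyphenyl gives a 13-fold lower number from compound 1 to compound 4 (1.12 log units; beyond the scatter), so the aromatic carbon para to a large group is not indifferent to what it carries. The earlier compounds shown here did not show this: compound 1 gives 40 nM and compound 2 gives 40 nM, which left the values level despite a different group in the same part of the molecule. The counted difference in this step is small, with methoxy bringing an oxygen and a hydrogen-bond acceptor that methyl does not have, yet none of the data shown accounts for the size of the step.

As far as these compounds go, with this single pair, it remains open whether the gain belongs to methoxy alone or would also appear with a hydroxy, an ethoxy or a dimethylamino group at the same aromatic carbon. From the compounds shown here alone, it is also open whether the low number of compound 4 would survive with a carboxylic acid in place of the methyl ester.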